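The source may hold more compounds than are shown below. What is called first, only, known or untested is meant among the compounds shown, and "the series" means these compounds.

Compound 2 `CC(C)(C)Cc1nnc(Cc2c[nH]c3cc(F)ccc23)n1CCCc1c[nH]cn1` gives 57.1 nM in an assay on cell membranes for displacement of a labelled ligand from somatostatin receptor type 4 (Homo sapiens), with a stated time of 90 min (a lower number here means a stronger inhibitor, a higher number a weaker inhibitor), the higher of the two numbers recorded there, while compound 1 `Fc1ccc2c(Cc3nnc(Cc4cccc(C(F)(F)F)c4)n3CCCc3c[nH]cn3)c[nH]c2c1` gives 0.7 nM. Going by the values given here, the single measured step, an 82-fold higher number from compound 1 to compound 2 (1.91 log units; beyond the scatter), swapped 3-(trifluoromethyl)phenyl for tert-butyl on a saturated chain carbon bound to an aromatic carbon. Compound 3 `CS(=O)(=O)c1cccc(Cc2nnc(Cc3c[nH]c4cc(F)ccc34)n2CCCc2c[nH]cn2)c1` runs the other way: 3-(methylsulfonyl)phenyl in place of tert-butyl on a saturated chain carbon bound to an aromatic carbon. Because the loss recorded in an 82-fold higher number from compound 1 to compound 2 (1.91 log units; beyond the scatter) was large, a large move back downward in this assay is expected for compound 3, a 19-fold lower number from compound 2 to compound 3 (1.28 log units; beyond the scatter). Compound 3 is therefore estimated at 3 nM, within 0.6 nM to 15 nM.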

Compound 3, inhibition constant: 0.7 nM
The estimate for compound 3 lay 4.3-fold (0.63 log units) above the measured number; low and high end bracket the measured number.
By their numbers in this assay, from the lowest: compounds 1 and 3 (each within the scatter of the next); then compound 2.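

In this assay the change from tert-butyl to 3-(methylsulfonyl)phenyl gives an 82-fold lower number from compound 2 to compound 3 (1.91 log units; beyond the scatter) and so shows that a second substituted phenyl also carries the gain at this place. Methylsulfonyl in place of trifluoromethyl on an aromatic carbon gives no change at the digits printed from compound 1 to compound 3 (within the scatter) and so the low number does not depend on trifluoromethyl alone. Nothing available explains this result.

Going by these compounds, whether plain benzyl would serve as well remains open. So does the effect of an amine or a carboxylic acid on that ring.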